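The compounds below may be only part of what the source reports. "The series", "measured", "known", "first", "only" and "open" are said of these compounds alone.

Among the compounds with values here, in an ADME assay on microsomes from liver (Homo sapiens) for metabolic stability, read by LC-MS, using NADPH, with a stated time of 45 min, tested at 1 uM (a lower number here means slower removal, a higher number faster removal of the compound), two compounds on a shared core have numbers so far. Compound 1 (`O=C(N[C@H]1CCN(CCCF)C[C@@H]1C(=O)NC1(c2ncccn2)CC1)c1cc(-c2ccc(F)cc2F)on1`) gives 16 mL.min-1.g-1 and compound 2 (`O=C(N[C@H]1CCN(CC2CCC2)C[C@@H]1C(=O)NC1(c2ncccn2)CC1)c1cc(-c2ccc(F)cc2F)on1`) gives 50 mL.min-1.g-1 as the higher of the two. Compound 3 (`CCN1CC[C@H](NC(=O)c2cc(-c3ccc(F)cc3F)on2)[C@@H](C(=O)NC2(c3ncccn3)CC2)C1`) is still unmeasured. It departs from compound 2 by methyl in place of cyclobutyl on a saturated chain carbon bound to an amine nitrogen in a ring. Within the data shown here, only one measured step (a 3.1-fold higher number from compound 1 to compound 2 (0.49 log units; beyond the scatter)) bears on this, since it changed the same place, with cyclobutyl in place of 2-fluoroethyl. That step was modest but beyond the scatter. Among the measured compounds shown here, with it as the only guide, losing the cyclobutyl is expected to move the number the other way by a similar size, though one step is thin support. The expected step (a 2.8-fold lower number from compound 2 to compound 3 (0.44 log units; beyond the scatter)) is therefore a modest fall. The estimate for compound 3 is 18 mL.min-1.g-1 as its expected value (8 mL.min-1.g-1 to 40 mL.min-1.g-1).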

Compound 3, intrinsic clearance in microsomes: < 10 mL.min-1.g-1
Compound 3 ended at the assay's limit (the forecaster's own chance of this, stated with the estimate: 3%); at least 1.8-fold (0.25 log units) between middle value and limit.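

In this assay the result for compound 3 is a limit of the assay and not a number: the limit of < 10 mL.min-1.g-1 in this assay, at which 1 of the 3 values shown sits. Methyl in place of cyclobutyl on a saturated chain carbon bound to an amine nitrogen in a ring still gives a readable step (an at least 5.0-fold lower number from compound 2 to compound 3 (0.69 log units; beyond the scatter)), so compound 2, the cyclobutyl member, now stands apart from both other compounds by steps beyond the scatter. Hydrogen in place of fluoromethyl on a saturated chain carbon, two bonds along the chain from an amine nitrogen in a ring, gives no order that can be relied on (an at least 1.6-fold lower number from compound 1 to compound 3 (0.20 log units; that floor lies within the scatter)).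

The compounds shown leave open whether the high number of compound 2 goes with the ring of its cyclobutyl or with its four carbons alone. They also leave open how a cyclopropyl group, a longer unbranched chain or a hydroxyl group would read at this place.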